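The source may hold more compounds than are shown below. What is called first, only, known or untested is meant among the compounds shown, and "the series" means these compounds.

Measured so far in a functional assay on Vero cells (Chlorocebus sabaeus) for inhibition; on this read-out higher numbers stand for weaker inhibition and lower numbers for stronger inhibition:
Compound 1 `OC[C@H]1O[C@@H](n2cnc3c(O)ncnc32)CS1` gives > 100000 nM, a limit of the assay.
Compound 2 `Nc1nc(Cl)c2ncn([C@@H]3CS[C@@H](CO)O3)c2n1` gives > 100000 nM, likewise a limit.
Compound 3 `OC[C@H]1O[C@H](n2cnc3c(Cl)ncnc32)CS1` gives 86100 nM.

Compound 3 and compound 2 differ in one place, (amino in place of hydrogen on an aromatic carbon). The step of an at least 1.1-fold higher number from compound 3 to compound 2 (0.06 log units; that floor lies within the scatter). That floor rests on the fact that (the limit of > 100000 nM in this assay, at which 2 of the 3 values shown sit). Compound 1 and compound 3 differ in more than one place; the difference between the two cores is not broken down here.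

Compound 4 `Nc1nc(O)c2ncn([C@H]3CS[C@@H](CO)O3)c2n1` is not yet measured in this assay. It differs from compound 1 by amino in place of hydrogen on an aromatic carbon. This is the same kind of change as that from compound 3 to compound 2, though the surroundings differ: meta to a hydroxy group in compound 4, meta to a chloro group in compound 2. The step expected from compound 1 to compound 4 is a step that the limit leaves unreadable from compound 1 to compound 4, resting on the measured step of an at least 1.1-fold higher number from compound 3 to compound 2 (0.06 log units; that floor lies within the scatter). Because compound 1 already gives > 100000 nM, a limit, compound 4 is expected most likely to return only a limit as well. Compound 4 is estimated at 150000 nM, with a range from 80000 nM to 400000 nM.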

Compound 4, half-maximal inhibitory concentration: > 100000 nM
Compound 4 gave a limit, no number (the forecaster's own chance of this, stated with the estimate: 85%); the middle value is on the limit's open side.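

Compound 1 and compound 4 both return only a limit in this assay, so no new step can be read for amino in place of hydrogen on an aromatic carbon: the limit of > 100000 nM in this assay, at which 3 of the 4 values shown sit.

The compounds shown leave open whether this change shifts inhibition in either direction on the core of compound 1, with no measured number on either side of it.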